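Swapping an Aromatic Thiadiazole for a Thiazolinone Ring

This account rests on a few compounds, and the source may have more. Where it says the series, first, only, none or still open, it means among the compounds named here.

Three measured compounds share one core and differ only in the group on the amide-type nitrogen. Compound 1 `CC(C)[C@H](C(=O)NCc1ccccc1)c1ccc(Cl)cc1` carries a benzyl group there. In a functional assay on CHO cells for agonist activity at Free fatty acid receptor 2 (Homo sapiens), read by cAMP accumulation (on this read-out higher numbers stand for weaker inhibition and lower numbers for stronger inhibition), compound 1 gives > 100000 nM, which is a limit of the assay and not a number. Compound 2 `CC(C)[C@H](C(=O)Nc1ccccn1)c1ccc(Cl)cc1` carries a pyridin-2-yl group and gives 1400 nM in this assay. Compound 3 `CC(C)[C@H](C(=O)Nc1nncs1)c1ccc(Cl)cc1` carries a 1,3,4-thiadiazol-2-yl group and gives 12000 nM in this assay, the highest of the two numbers seen; its nearest neighbour is compound 2, and the step of an 8.6-fold higher number from compound 2 to compound 3 (0.93 log units; beyond the scatter) lies beyond the scatter.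

Compound 4 `CC(C)[C@H](C(=O)NC1=NC(=O)CS1)c1ccc(Cl)cc1` is not yet measured. Its change from compound 3 is a group of 6 heavy atoms (3 carbon, 1 nitrogen, 1 oxygen, 1 sulfur; one five-membered non-aromatic ring with 2 hetero atoms) in place of a group of 5 heavy atoms (2 carbon, 2 nitrogen, 1 sulfur; one five-membered aromatic ring with 3 hetero atoms), on an amide-type nitrogen. The measured steps of an at least 71-fold lower number from compound 1 to compound 2 (1.85 log units; beyond the scatter), an at least 8.3-fold lower number from compound 1 to compound 3 (0.92 log units; beyond the scatter) and an 8.6-fold higher number from compound 2 to compound 3 (0.93 log units; beyond the scatter) all exchange the whole group on that nitrogen and show that such swaps can move the number well beyond the scatter in either direction. For the measured compounds named here, none of them, however, keeps a five-membered sulfur-containing ring while giving up its aromatic character, so no measured step bears directly on this change. The expected step of a 1.2-fold lower number from compound 3 to compound 4 (0.08 log units; within the scatter) is therefore small, with wide uncertainty. In this assay compound 4 is expected to give about 10000 nM, within 2000 nM to 50000 nM.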

Compound 4, half-maximal inhibitory concentration: 20000 nM
Beside the measured number, compound 4's estimate is 2.0-fold (0.30 log units) below it; low and high end bracket the measured number.
By their numbers in this assay, from the lowest: compound 2; then compounds 3 and 4 (each within the scatter of the next). At a limit, above all of these: compound 1.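

In this assay, the step of a 1.7-fold higher number from compound 3 to compound 4 (0.22 log units; within the scatter) shows that the aromatic 1,3,4-thiadiazol-2-yl ring can be exchanged for a non-aromatic five-membered sulfur-containing ring on this amide-type nitrogen without a change beyond the scatter, so aromatic character in that five-membered ring is not required to stay at the level of compound 3. The new ring does not close the gap to the pyridin-2-yl group, as the step of a 14-fold higher number from compound 2 to compound 4 (1.15 log units; beyond the scatter) shows, and compound 2 keeps the lowest number of the series. The step of an at least 5.0-fold lower number from compound 1 to compound 4 (0.69 log units; beyond the scatter) places the new ring clear of the benzyl group, but it gives only a bound, since the value for compound 1 is a limit and not a number: the limit of > 100000 nM in this assay, at which 1 of the 4 values shown sits.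

The compounds shown leave open whether the carbonyl of the new ring contributes anything, since no matching ring without it, such as a plain thiazolidine, appears here. They also leave open whether other six-membered aromatic rings, such as pyrimidin-2-yl, or a pyridin-2-yl ring carrying a methyl or a carboxylic acid, would go below the number of compound 2.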